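Chloro to bromo on a trifluoromethyl compound

The compounds below may be only part of what the source reports. "The series", "measured", "known", "first", "only" and "open" are said of these compounds alone.

In an ADME assay on BHK-21 cells (Mesocricetus auratus) for cytotoxicity, read by MTT assay, with a stated time of 72 h (on this read-out higher numbers stand for lower toxicity in this test and lower numbers for higher toxicity in this test), compound 1 (`FC(F)(F)c1ccc(-c2nn(-c3ccccc3)cc2CNc2ccc(Cl)cc2)cc1`) gives 31000 nM, the lowest number in this small set. Compound 2 (`Clc1ccc(NCc2cn(-c3ccccc3)nc2-c2ccc(Cl)cc2)cc1`) gives 73000 nM. Compound 3 (`Cc1ccc(-c2nn(-c3ccccc3)cc2CNc2ccc(Cl)cc2)cc1`) reaches only a limit of the assay, > 100000 nM.

Compound 4 (`FC(F)(F)c1ccc(-c2nn(-c3ccccc3)cc2CNc2ccc(Br)cc2)cc1`) keeps the trifluoromethyl group of compound 1 and differs from it in one place: bromo in place of chloro on an aromatic carbon. The (4-chlorophenyl)amino group thus becomes (4-bromophenyl)amino.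

For the measured compounds named here, no measured step tests this swap directly, as all three measured compounds carry the same (4-chlorophenyl)amino group. The nearest guidance comes from replacing the trifluoromethyl group instead. Chloro there gives a 2.4-fold higher number from compound 1 to compound 2 (0.37 log units; beyond the scatter), and methyl there gives an at least 3.2-fold higher number from compound 1 to compound 3 (0.50 log units; beyond the scatter). Exchanging those two replacements gives an at least 1.3-fold higher number from compound 2 to compound 3 (0.13 log units; that floor lies within the scatter). These steps show that one swapped group moved this read-out only modestly in these compounds, although they concern a different group. On that indirect basis, no shift beyond the usual scatter is expected, and the estimated step is a 1.1-fold lower number from compound 1 to compound 4 (0.03 log units; within the scatter). For compound 4, the estimated value is 29000 nM, with an expected range from 13000 nM to 65000 nM.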

Compound 4, half-maximal cytotoxic concentration: 28000 nM
Beside the measured number, compound 4's estimate is 1.0-fold (0.02 log units) above it; the measured number falls inside the stated range.
By their numbers in this assay, from the lowest: compounds 4 and 1 (each within the scatter of the next); then compound 2. At a limit, above all of these: compound 3.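

The earlier steps all replaced the trifluoromethyl group, and one of them gave a 2.4-fold higher number from compound 1 to compound 2 (0.37 log units; beyond the scatter) while this is the only step shown at the 4-chlorophenyl group. In this assay bromo in place of chloro gives a 1.1-fold lower number from compound 1 to compound 4 (0.04 log units; within the scatter) so on this trifluoromethyl compound, the two halogens cannot be told apart at this aromatic carbon. Nothing measured here explains why this swap leaves the read-out within the scatter while the trifluoromethyl replacement in compound 2 does not.

Going by these compounds, it remains open whether bromo in place of chloro would behave the same way in compound 2 or compound 3, where chloro or methyl stands in place of trifluoromethyl. A group of a different kind on this aromatic carbon, such as a methoxy group, an amine or a carboxylic acid, might also shift the number in this assay and the compounds shown cannot say whether the flat result holds beyond the two halogens.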